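The source may report more compounds than this note shows. Statements on the series, on what has been measured and on what is new or still open speak of the compounds shown alone.

Among the compounds with values here, compound 1 `O=C(CN1CCN(c2ccccn2)CC1)Nc1cccnc1` holds the only number in hand: in a functional assay on cells for agonist activity at D(4) dopamine receptor (Homo sapiens), read by TR-FRET and cAMP accumulation, with a stated time of 30 min (on this read-out lower numbers stand for an effect already at smaller amounts and higher numbers for an effect only at larger amounts of compound), compound 1 gives 1080 nM. Compound 2 `Cc1ccc(C2CCN(CC(=O)Nc3cccc(C)c3)CC2)cc1` is the other entry; in this assay compound 2 is reported as "not active" (no number reported), with no figure attached. Compound 3 `Cc1cccc(NC(=O)CN2CCN(c3ccccn3)CC2)c1` differs from compound 1 by 3-methylphenyl in place of pyridin-3-yl on an amide-type nitrogen. Within the data shown here, no step between measured compounds is available, so the size of such a change cannot be read from the data. The expectation for compound 3 is a step of a 2.3-fold higher number from compound 1 to compound 3 (0.36 log units; beyond the scatter) toward weaker activity, modest but beyond the usual scatter. Compound 3 is estimated at 2500 nM in this assay, with a range from 700 nM to 9000 nM.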

Compound 3, half-maximal effective concentration: 3.6 nM
For compound 3 the middle estimate is 690-fold (2.84 log units) above the measured one; the measured number lies below the stated range.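

Placing 3-methylphenyl in place of pyridin-3-yl on an amide-type nitrogen gives a 300-fold lower number from compound 1 to compound 3 (2.48 log units; beyond the scatter) in this assay and shows that this position can govern activity on the shared core. Within the data shown here, the single earlier number could not reveal this sensitivity, and the step is large and beyond the scatter. Nothing available accounts for its size.

The compounds shown leave open whether the gain follows from the methyl group or from the ring of carbon only. Plain phenyl on the same nitrogen would separate these two changes.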